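Compound 2 to compound 3: an exchange on the carbonyl carbon

This account rests on a few compounds, and the source may have more. Where it says the series, first, only, none or still open, it means among the compounds named here.

Compound 1 (`C[C@]1(C(=O)O)CC[C@H](C(=O)N2CC[C@](c3ccc(C(F)(C(F)(F)F)C(F)(F)F)cc3)(S(=O)(=O)c3ccc(F)cc3)C2)CC1`) gives 93% in an ADME assay on microsomes from liver (Mus musculus) for metabolic stability, with a stated time of 10 min (a lower number here means that less of the compound is left, a higher number that more of the compound is left), and is the only measured point so far. Compound 2 (`CC[C@]1(C(=O)O)CC[C@H](C(=O)N2CC[C@](c3ccc(C(F)(C(F)(F)F)C(F)(F)F)cc3)(S(=O)(=O)c3ccc(F)cc3)C2)CC1`) stands at "not determined" (no result reported) and so has no number to place it. Compound 3 (`COC[C@]1(C(=O)N2CC[C@](c3ccc(C(F)(C(F)(F)F)C(F)(F)F)cc3)(S(=O)(=O)c3ccc(F)cc3)C2)CC[C@H](C(=O)O)CC1`) follows from compound 2 by 4-carboxy-1-(methoxymethyl)cyclohexyl in place of 4-carboxy-4-ethylcyclohexyl on a carbonyl carbon with 4-carboxy-1-(methoxymethyl)cyclohexyl in place of 4-carboxy-4-ethylcyclohexyl on a carbonyl carbon. For the measured compounds named here, no measured step covers this change, so none beyond the scatter is expected in this assay in either direction, the sole reference being compound 1 at 93% here. Compound 3 is estimated at 88% within a range of 70% to 98% in this reading.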

Compound 3, percent of the compound remaining: 88%
The estimate for compound 3 equals the measured number at the digits printed; measured number inside the range.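

In this assay the exchange of 4-carboxy-4-methylcyclohexyl for 4-carboxy-1-(methoxymethyl)cyclohexyl on the carbonyl carbon gives a number 5 percentage points lower from compound 1 to compound 3 (within the scatter). For the compounds shown here, this is the first readable step at this position, and it shows that the exchange, with its additional oxygen, leaves the read-out within the usual scatter. The available evidence offers no explanation for this result. Going by these compounds, whether an amine or a longer chain in place of the methoxymethyl group would also stay within the scatter in this assay remains open. On these data alone, the role of the carboxylic acid on the cyclohexyl ring also remains open.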